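The compounds below may be only part of what the source reports. "The series", "measured", "known", "first", "only" and "open" are said of these compounds alone.

Measured so far:
Compound 1, `CCCOc1nc(N)nc2c1ncn2/C=C1/CC1(CO)CO`: in an ADME assay on HFF cells (Homo sapiens) for cytotoxicity, with a stated time of 8 days (on this read-out lower numbers stand for higher toxicity in this test and higher numbers for lower toxicity in this test), compound 1 gives > 300000 nM, which is a limit of the assay and not a number.
Compound 2, `Nc1nc(OCC(F)(F)F)c2ncn(/C=C3/CC3(CO)CO)c2n1`: in this assay compound 2 gives > 300000 nM, again a limit.
Compound 3, `Nc1nc(N2CCCC2)c2ncn(/C=C3/CC3(CO)CO)c2n1`: in this assay compound 3 gives > 300000 nM, also a limit.

Compound 3 therefore stands only at a limit, and so do the other two values; all three sit at the limit of > 300000 nM in this assay, at which 3 of the 3 values shown sit. The steps leading into compound 3 are a step that the two limits leave unreadable from compound 1 to compound 3 and a step that the two limits leave unreadable from compound 2 to compound 3, and the remaining step that the two limits leave unreadable from compound 1 to compound 2 is unreadable as well, so none of them gives a size that could be carried over.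

The unmeasured compound 4 is `CCCCCCOc1nc(N)nc2c1ncn2/C=C1/CC1(CO)CO`. Its change from compound 3 is hexyloxy in place of pyrrolidin-1-yl on an aromatic carbon. No measured step bears readably on this change, and nothing shown moves any compound off the limit, so no step beyond the scatter is expected in this assay in either direction. Compound 4 is therefore estimated at 300000 nM, with a range from 100000 nM to 1000000 nM, most likely reported again as a limit. The estimated step is a number no higher from compound 3 to compound 4 (the limit leaves the size open).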

Compound 4, half-maximal cytotoxic concentration: > 200000 nM
Compound 4: a limit, no number; the forecaster's own chance of this, stated with the estimate: 80%; the middle value does not contradict the limit.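

Compound 4, like compound 1, compound 2 and compound 3, stands only at a limit in this assay, so none of the steps from those three to compound 4 can be read. The compounds shown leave open whether any change at this place alters the half-maximal cytotoxic concentration at all.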